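The source may hold more compounds than are shown below. What is called first, only, known or untested is meant among the compounds shown, and "the series" means these compounds.

Compound 3, a macrocycle with a phenyl group on the side chain and an ether-linked aromatic bridge `CCC[C@@H]1NC(=O)[C@@H](C(C)C)NC(=O)[C@@H](Cc2ccccc2)NCCOc2ccccc2CCCNC1=O`, was examined in an assay on isolated protein for displacement of a labelled ligand from Motilin receptor (Homo sapiens) (a lower number here means a stronger inhibitor, a higher number a weaker inhibitor), and gave 57 nM. Two related macrocycles carrying a hydroxyphenyl side chain and an alkene-containing bridge sit far away: compound 1 `CCC[C@@H]1NC(=O)[C@@H](C(C)C)NC(=O)[C@@H](Cc2ccc(O)cc2)NCCCc2ccccc2/C=C\CCNC1=O` gives 7300 nM in this assay, and compound 2 `CCC[C@@H]1NC(=O)[C@@H](C(C)C)NC(=O)[C@@H](Cc2ccc(O)cc2)NCCc2ccccc2/C=C/CNC1=O` gives 9730 nM. Compound 3 therefore stands with the lowest of the three numbers, and both gaps to the other compounds lie well beyond the scatter; compound 1 is the nearer of the two and compound 2 the further.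

Compound 4 `CCC[C@@H]1NC(=O)[C@@H](C(C)C)NC(=O)[C@@H](CCc2ccccc2)NCCOc2ccccc2CCCNC1=O` keeps the core of compound 3 and changes only the side chain: benzyl in place of phenyl on a saturated chain carbon bound to a saturated ring carbon. Among the measured compounds shown here, no measured pair in this set shows what such a homologation does, so the expectation rests on compound 3 alone. Because compound 3 gives 57 nM and the change adds a single chain carbon without altering donors, acceptors or charge, the step from compound 3 to compound 4 is expected to be modest, most likely toward a somewhat higher number, though it could stay within the scatter; the estimated step is a 2.6-fold higher number from compound 3 to compound 4 (0.42 log units; beyond the scatter). Compound 4 is accordingly estimated at 150 nM in this assay, with a range from 30 nM to 800 nM.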

Compound 4, inhibition constant: 1490 nM
Estimate against measurement, compound 4: 9.9-fold (1.00 log units) below; measured number above the stated range.
By their numbers in this assay, from the lowest: compound 3; then compound 4; then compounds 1 and 2 (each within the scatter of the next).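

In this assay, among the compounds shown here, benzyl in place of phenyl on a saturated chain carbon bound to a saturated ring carbon is the first change in this set that can be read in one place, and it gives a 26-fold higher number from compound 3 to compound 4 (1.42 log units; beyond the scatter) as a large step. The position therefore does not tolerate this change freely: the entering and leaving groups carry the same aromatic ring, the same counts of hydrogen-bond donors and acceptors and no net charge, and differ only in heavy atoms, 7 against 6, yet the number rises well beyond the scatter. Nothing given here explains why so small a difference in the side chain carries so large a step.

From the compounds shown here alone, it remains open whether a longer chain, such as phenylpropyl, would raise the number further, and whether an amine or a carboxylic acid at the end of this chain would be accepted in place of the aromatic ring. Compounds 1 and 2 differ from compound 3 and compound 4 in more than one place, so they cannot show whether the same change would have a similar size on their hydroxyphenyl side chains and alkene-containing bridges.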